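The source may report more compounds than this note shows. Statements on the series, on what has been measured and on what is new or still open speak of the compounds shown alone.

Compound 1 `COc1ccccc1/C=C(/SCc1ccc(Cl)cc1)C(=O)c1ccc(Cl)cc1` is the reference point in a functional assay on DU-145 cells (Homo sapiens) for inhibition, read by trypan blue exclusion, with a stated time of 96 h; a higher number here means a weaker inhibitor of growth, a lower number a stronger inhibitor of growth. In this assay compound 1 gives 1000 nM, the lowest of the two numbers in hand. Compound 3 `O=C(/C(=C\c1ccc(O)cc1)SCc1ccc(Cl)cc1)c1ccc(Cl)cc1` in this assay gives 10000 nM. Compound 2 `CN(C)c1ccc(/C=C(/SCc2ccc(Cl)cc2)C(=O)c2ccc(Cl)cc2)cc1` in this assay gives only a limit, > 100000 nM, and no number. Compound 2 thus sits at the limit of > 100000 nM in this assay, at which 1 of the 3 values shown sits. Every step measured so far alters the aryl on the double-bonded chain carbon: a 10-fold higher number from compound 1 to compound 3 (1.00 log units; beyond the scatter); an at least 100-fold higher number from compound 1 to compound 2 (2.00 log units; beyond the scatter); an at least 10-fold lower number from compound 2 to compound 3 (1.00 log units; beyond the scatter).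

Compound 4 `COc1ccccc1/C=C(/SCc1ccc(Cl)cc1)C(=O)c1ccc(Br)cc1` differs from compound 1 at another place: bromo in place of chloro on an aromatic carbon. Among the compounds with values here, none of the measured steps touches the (4-chlorophenyl)carbonyl; they give no guide to this change in either direction, and the change itself is small in what it counts. In this assay the step is therefore expected to stay within the scatter. Compound 4 is expected to give 1000 nM, with a range from 400 nM to 2500 nM. The estimate means a step of no change at the digits printed from compound 1 to compound 4 (within the scatter), expected to be within the scatter.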

Compound 4, concentration for 50% growth inhibition: 1000 nM
Compound 4: middle estimate and measured number agree at the digits printed; the measured number falls inside the stated range.
By their numbers in this assay, from the lowest: compounds 1 and 4 (each within the scatter of the next); then compound 3. At a limit, above all of these: compound 2.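

At the (4-chlorophenyl)carbonyl, the first place tested away from the aryl on the double-bonded chain carbon, bromo in place of chloro gives no change at the digits printed from compound 1 to compound 4 (within the scatter) in this assay. All earlier steps altered that aryl and lay beyond the scatter, so the series now has its first change that leaves the reading within the scatter. This shows only that chloro and bromo read alike at this one place on the core of compound 1; it does not show that the place accepts other groups.

Still open, from the compounds shown here alone, is how a carboxylic acid, an amine or a methoxy group would read in place of the chloro of compound 1, and whether the second 4-chlorophenyl of the core allows the same exchange. No measurement shown bears on why the chloro and bromo compounds read alike.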